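Acetylated and free hydroxylamine enones in the series

This account rests on a few compounds, and the source may have more. Where it says the series, first, only, none or still open, it means among the compounds named here.

- compound 1 `O=C(/C=C\N(O)Cc1ccccc1)c1ccc([N+](=O)[O-])cc1`: 2500 nM
- compound 2 `CC(=O)ON(/C=C\C(=O)c1ccc(F)cc1)Cc1ccccc1`: > 25000 nM
- compound 3 `CN(O)/C=C\C(=O)c1ccc(OCc2ccccn2)cc1`: 10000 nM

Three compounds have been run in an assay on RBL-1 cells for inhibition of Polyunsaturated fatty acid 5-lipoxygenase (Rattus norvegicus); a lower number here means a stronger inhibitor, a higher number a weaker inhibitor. Compound 1 carries the free hydroxyl on nitrogen together with the nitro group and gives 2500 nM. Compound 3 replaces the benzyl by methyl and gives 10000 nM. For the measured compounds named here, for compound 2 only a limit is available: it sits at > 25000 nM, which is the limit of this assay and not a number; it is the one value that rests at the limit of > 25000 nM in this assay, at which 1 of the 3 values shown sits.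

Compound 4 `CC(=O)ON(/C=C\C(=O)c1ccc([N+](=O)[O-])cc1)Cc1ccccc1` is not yet measured. It keeps the acetylated hydroxylamine of compound 2 and differs by nitro in place of fluoro on an aromatic carbon, in words: nitro in place of fluoro on an aromatic carbon. Going by the values given here, no step between measured compounds covers this change. Among the compounds with values here, the nitro group appears in compound 1 alongside the free hydroxyl, but no pair here isolates the nitro-for-fluoro swap itself.

The expectation for compound 4 is a value close to where compound 2 stands, so the estimated step of an at least 1.2-fold lower number from compound 2 to compound 4 (0.09 log units; that floor lies within the scatter) is small and may not exceed the scatter. Compound 4 is estimated at 20000 nM, with a range from 5000 nM to 60000 nM.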

Compound 4, half-maximal inhibitory concentration: > 25000 nM
Compound 4: only a limit was reported; the forecaster's own chance of this, stated with the estimate: 55%; at least 1.2-fold (0.09 log units) between middle value and limit.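

With the nitro group held fixed, acetyl in place of hydrogen on the oxygen gives an at least 10-fold higher number from compound 1 to compound 4 (1.00 log units; beyond the scatter) in this assay, and this step lies beyond the scatter. For the compounds shown here, it is the first pair that isolates this change on the hydroxylamine, and it shows that the acetylated nitro compound loses inhibition relative to its free hydroxyl partner. The value of compound 4 is a limit of the assay and not a number, and the step for nitro in place of fluoro on the aromatic carbon cannot be read, because compound 2 and compound 4 both rest there: the limit of > 25000 nM in this assay, at which 2 of the 4 values shown sit.

The compounds shown leave open how far beyond the limit the two acetylated compounds lie, and whether nitro or fluoro on the aromatic carbon matters at all once the oxygen carries a free hydrogen. Also open, on these data alone, is whether the loss belongs to acetyl alone or extends to other groups on that oxygen, such as a methyl ether or a longer acyl chain like butyryl.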